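Nitro on the anilide of a thiourea core

A few compounds are considered here, and "the series" means these few. Any claim that something is new, unique, unknown or untested is made for them only; others in the source may bear on it.

For the measured compounds named here, compound 1 `CC1=C(C(=O)Nc2ccccc2)C(c2cn(-c3ccccc3)nc2-c2ccccc2)NC(=S)N1` is the weaker of the two measured members of this pair. In a functional assay on MCF7 cells (Homo sapiens) for inhibition, read by sulforhodamine B assay, with a stated time of 24 h (on this read-out lower numbers stand for stronger inhibition of growth and higher numbers for weaker inhibition of growth), compound 1 gives 88200 nM, the highest number on record here. Its nearest neighbour, compound 2 `CC1=C(C(=O)Nc2ccc([N+](=O)[O-])cc2)C(c2cn(-c3ccccc3)nc2-c2ccccc2)NC(=O)N1`, gives 35500 nM in this assay, a lower number that lies beyond the scatter; compound 2, however, differs from compound 1 in more than one place, so no single change can be read from that gap.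

Compound 3 `CC1=C(C(=O)Nc2ccc([N+](=O)[O-])cc2)C(c2cn(-c3ccccc3)nc2-c2ccccc2)NC(=S)N1` changes compound 1 in one place only: nitro in place of hydrogen on an aromatic carbon of the anilide ring. Given the lower number of compound 2 in this assay, a modest step toward a lower number is expected from compound 1 to compound 3, a 1.8-fold lower number from compound 1 to compound 3 (0.25 log units; within the scatter), though not certainly beyond the scatter. Compound 3 is accordingly estimated at 50000 nM, within a range of 20000 nM to 125000 nM.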

Compound 3, concentration for 50% growth inhibition: 41400 nM
Compound 3: middle estimate off by 1.2-fold (0.08 log units), on the high side, and the stated range covers the measured number.
By their numbers in this assay, from the lowest: compounds 2 and 3 (each within the scatter of the next); then compound 1.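

In this assay the series now has its first change read in one place: nitro in place of hydrogen on the anilide ring gives a 2.1-fold lower number from compound 1 to compound 3 (0.33 log units; beyond the scatter) and so moves the number by a modest step, showing that this aromatic carbon, para to a large group, is not silent to substitution. Compound 3 gives 41400 nM and compound 2, which carries the same 4-nitrophenyl group but has oxygen in place of the sulfur on the core, gives 35500 nM and the two lie within the scatter of each other. Nothing measured here accounts for the step.

As far as these compounds go, whether the step belongs to nitro itself remains open; an amine, a methoxy group or a chlorine on the same carbon would test that. The oxygen counterpart of compound 1 would show whether the exchange of sulfur for oxygen matters on the plain phenyl anilide.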